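Adding a Bromo Group to Compound 1

The source may report more compounds than this note shows. Statements on the series, on what has been measured and on what is new or still open speak of the compounds shown alone.

In a functional assay on HepG2 cells (Homo sapiens) for cytotoxicity, read by MTT assay, with a stated time of 48 h (on this read-out lower numbers stand for stronger inhibition and higher numbers for weaker inhibition), compound 1 (`O=C(CSc1ccccc1)N1N=C(c2cc3ccccc3oc2=O)C[C@@H]1c1ccccc1`) gives 16300 nM. Going by the values given here, the only other measured compound, compound 2 (`CC1=NN(C(=O)CSc2ccccn2)[C@@H](c2cc(Br)cc(Br)c2O)C1`), gives 24700 nM. These two values lie within the usual scatter of each other, so the data cannot separate compound 1 from compound 2. Compound 3 (`O=C(CSc1ccc(Br)cc1)N1N=C(c2cc3ccccc3oc2=O)C[C@@H]1c1ccccc1`) keeps the core of compound 1 and differs in one place: phenylsulfanyl becomes (4-bromophenyl)sulfanyl, with bromo in place of hydrogen on an aromatic carbon, para to a large group (bromo in place of hydrogen on an aromatic carbon). Among the compounds with values here, no measured pair shows this change, so its size has no direct guide here. In this assay, only a small move toward lower numbers is expected, hardly beyond the scatter. The estimated change is a 1.4-fold lower number from compound 1 to compound 3 (0.13 log units; within the scatter). The expected value for compound 3 is 12000 nM, with an estimated range from 5000 nM to 28000 nM.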

Compound 3, half-maximal inhibitory concentration: 14500 nM
Compound 3: middle estimate off by 1.2-fold (0.08 log units), on the low side; measured number inside the range.
By their numbers in this assay, from the lowest: compounds 3, 1 and 2 (each within the scatter of the next).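

Bromo in place of hydrogen on an aromatic carbon, para to a large group, now has a direct reading in this assay: a 1.1-fold lower number from compound 1 to compound 3 (0.05 log units; within the scatter). Turning phenylsulfanyl into (4-bromophenyl)sulfanyl on the core of compound 1 therefore gives no change that this assay can separate from the scatter, so the step shows that this position accepts a bromo group without a measurable shift in the number. No measurement on hand speaks to what lies behind this result. The compounds shown leave open whether a different group at this position, such as an amine, a carboxylic acid or a longer chain, would move the number beyond the scatter. They also leave open whether bromo would give the same result on another aromatic carbon or on a different core.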